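From Isopropyl to Hydrogen on a Ring Amine

The source may hold more compounds than are shown below. What is called first, only, known or untested is meant among the compounds shown, and "the series" means these compounds.

Going by the values given here, only two compounds have numbers so far. In a functional assay on PC-6 cells (Homo sapiens) for cytotoxicity, read by MTT assay, with a stated time of 3 days (a lower number here means a stronger inhibitor, a higher number a weaker inhibitor), compound 1 `CC(C)(C)c1cc2c(N/N=C/c3ccc(C(=O)O)cc3)ncnc2s1` gives 7.22 ug/mL, while compound 2 `CC(C)N1Cc2ccc(/C=N/Nc3ncnc4sc(C(C)(C)C)cc34)cc2C1` gives 0.134 ug/mL. Compound 2 therefore holds the lower of the two numbers, and the gap between them lies beyond the usual scatter of repeated measurements. These two compounds differ in more than one place, so their gap cannot be assigned to any single group.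

Compound 3 `CC(C)(C)c1cc2c(N/N=C/c3ccc4c(c3)CNC4)ncnc2s1` has not yet been measured in this assay. It departs from compound 2 in one place: hydrogen in place of isopropyl on an amine nitrogen in a ring. Put simply, it has hydrogen in place of isopropyl on an amine nitrogen in a ring. Among the compounds with values here, no measured pair tests this change, so the closest guide is compound 2 itself, at 0.134 ug/mL, whose structure compound 3 otherwise keeps. A small move toward a higher number is expected, with no clear step beyond the scatter. The estimated change is a 1.5-fold higher number from compound 2 to compound 3 (0.17 log units; within the scatter). For compound 3 the expected value is 0.2 ug/mL, within an estimated range of 0.06 ug/mL to 0.7 ug/mL.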

Compound 3, half-maximal inhibitory concentration: 0.071 ug/mL
Compound 3: the middle estimate sits 2.8-fold (0.45 log units) above what was measured; low and high end bracket the measured number.
By their numbers in this assay, from the lowest: compounds 3 and 2 (each within the scatter of the next); then compound 1.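

In this assay, going by these compounds alone, replacing isopropyl with hydrogen on the amine nitrogen in the ring gives a 1.9-fold lower number from compound 2 to compound 3 (0.28 log units; within the scatter), and this is the first pair that differs in only one place. Within the data shown here, it therefore gives the first direct reading of this position: the isopropyl group and its three carbon atoms can be removed with no change that stands out from the scatter of repeated measurements, so the pair shows that the change is tolerated, not that it brings a gain. No measurement shown here gives a reason for this result.

From the compounds shown here alone, two compounds are a narrow basis, and it remains open whether other groups on this nitrogen, such as methyl, acetyl or a longer chain, would also leave the number within the scatter. Going by these compounds, it also remains open whether the nitrogen itself matters, a question that a compound with a plain ring carbon in its place could answer.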